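Taking the (1-bromoethenyl)carbonyl group off compound 2

The source may hold more compounds than are shown below. What is called first, only, known or untested is meant among the compounds shown, and "the series" means these compounds.

In a functional assay on L1210 cells (Mus musculus) for antiproliferative activity, with a stated time of 48 h (on this read-out lower numbers stand for stronger inhibition and higher numbers for weaker inhibition), compound 2 (`C=C(Br)C(=O)Nc1ccc(/C=C/C(=O)c2cc(OC)c(OC)c(OC)c2)cc1`) gives 910 nM and stands level, within the scatter, with compound 3 (`C=C(Br)C(=O)Nc1ccc(C(=O)/C=C/c2ccccc2)cc1`) at 880 nM in this small set. Compound 1 (`C=C(Br)C(=O)Nc1ccc(/C=C/C(=O)c2ccc(Cl)c(Cl)c2)cc1`) gives a higher number, 2100 nM, beyond the scatter from compound 2. Compound 4 (`COc1cc(C(=O)/C=C/c2ccc(N)cc2)cc(OC)c1OC`) carries hydrogen in place of (1-bromoethenyl)carbonyl on a nitrogen on an aromatic ring. Among the compounds with values here, all three measured compounds keep that group, so no measured step shows what its loss does. The expected step in this assay is a 13-fold higher number from compound 2 to compound 4 (1.12 log units; beyond the scatter) (estimated), a large rise toward weaker inhibition, beyond the scatter. The estimate for compound 4 is 12000 nM (expected range 3000 nM to 50000 nM).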

Compound 4, half-maximal inhibitory concentration: 14000 nM
Estimate against measurement, compound 4: 1.2-fold (0.07 log units) below; low and high end bracket the measured number.
By their numbers in this assay, from the lowest: compounds 3 and 2 (each within the scatter of the next); then compound 1; then compound 4.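

Hydrogen in place of (1-bromoethenyl)carbonyl on the nitrogen gives a 15-fold higher number from compound 2 to compound 4 (1.19 log units; beyond the scatter) in this assay. This first step at this position shows that much of the inhibition of compound 2 is lost with the group, leaving the free amino compound. Nothing at hand explains the size of this step.

Which part of the group counts stays open: an acetyl group on the same nitrogen, lacking both bromine and the carbon-carbon double bond, would separate the carbonyl from the rest. Going by these compounds, whether the step carries over to the cores of compound 1 and compound 3 is also open.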